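Changing the chain link from compound 3 to compound 4

The compounds below may be only part of what the source reports. "The series", "measured", "known", "first", "only" and "open" are said of these compounds alone.

Measured so far in a functional assay on OVCAR-4 cells (Homo sapiens) for inhibition, read by sulforhodamine B assay, with a stated time of 48 h; on this read-out higher numbers stand for weaker inhibition of growth and lower numbers for stronger inhibition of growth
- compound 1 `CCCCCCCCCCCC[C@@H](O)[C@H]1CC[C@H]([C@H](O)CCCCCCCCCCN(C)C(=O)c2ccnn2C)O1` gives 10000 nM
- compound 2 `CCCCCCCCCCCC[C@@H](O)[C@H]1CC[C@H]([C@H](O)CCCCCCCCCCNCc2ccnn2C)O1` gives 1580 nM
- compound 3 `CCCCCCCCCCCC[C@@H](O)[C@H]1CC[C@H]([C@H](O)CCCCCCCCCCC(=O)Nc2ccnn2C)O1` gives 100000 nM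

Going by the values given here, compound 3 stands at the top of these numbers, and its 100000 nM is the highest value so far, which makes it the weakest inhibitor of growth of the three. The next change leads to compound 4 `CCCCCCCCCCCC[C@@H](O)[C@H]1CC[C@H]([C@H](O)CCCCCCCCCCOC(=O)c2ccnn2C)O1` and reads ((1-methyl-1H-pyrazol-5-yl)carbonyl)oxy in place of (1-methyl-1H-pyrazol-5-yl)carbamoyl on a saturated chain carbon, ten or more bonds along the chain from an oxygen on a saturated carbon and a saturated ring carbon on the same saturated chain carbon.

Compound 4 keeps the (1-methyl-1H-pyrazol-5-yl)carbonyl group found in compound 1, so the closest measured step is the modest one of a 10-fold higher number from compound 1 to compound 3 (1.00 log units; beyond the scatter) taken backwards. The steps of a 63-fold higher number from compound 2 to compound 3 (1.80 log units; beyond the scatter) and a 6.3-fold lower number from compound 1 to compound 2 (0.80 log units; beyond the scatter) both involve a ((1-methyl-1H-pyrazol-5-yl)methyl)amino group that compound 4 lacks, and they say less here. Among the compounds with values here, no measured compound carries ((1-methyl-1H-pyrazol-5-yl)carbonyl)oxy, so the expectation rests on compound 1 at 10000 nM as the nearest match only.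

A move to a lower number is expected in this assay and the estimated step is a 10-fold lower number from compound 3 to compound 4 (1.00 log units; beyond the scatter) with wide uncertainty. For compound 4 the expected value is 10000 nM within an estimated range of 2500 nM to 50000 nM for now.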

Compound 4, concentration for 50% growth inhibition: 100000 nM
Compound 4: middle estimate off by 10-fold (1.00 log units), on the low side; measured number above the stated range.
By their numbers in this assay, from the lowest: compound 2; then compound 1; then compounds 3 and 4 (each within the scatter of the next).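

In this assay, ((1-methyl-1H-pyrazol-5-yl)carbonyl)oxy in place of (1-methyl-1H-pyrazol-5-yl)carbamoyl gives no change at the digits printed from compound 3 to compound 4 (within the scatter), so at this saturated chain carbon the exchange of the carbamoyl link for the carbonyloxy link, with its different count of hydrogen-bond donors and acceptors, produces no readable shift. The carbonyl shared with compound 1 does not carry that compound's number over, as a 10-fold higher number from compound 1 to compound 4 (1.00 log units; beyond the scatter) shows, and the gap to the secondary amine is wider, at a 63-fold higher number from compound 2 to compound 4 (1.80 log units; beyond the scatter); among these four, the two compounds with a nitrogen on the chain carbon, compounds 1 and 2, give lower numbers than compounds 3 and 4, and none goes against this. No measurement shown here bears on the reason for this result.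

Still open, as far as these compounds go, is whether an ether link to the (1-methyl-1H-pyrazol-5-yl)methyl group would behave like the amine of compound 2 or like the carbonyloxy link of compound 4. Also open, from the compounds shown here alone, is how a tertiary amine carrying a methyl on that nitrogen, or a longer chain, would read in this assay.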